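Mirror-Image Ester in a PC-3 Antiproliferative Series

This account rests on a few compounds, and the source may have more. Where it says the series, first, only, none or still open, it means among the compounds named here.

Compound 1, `CC1(C)[C@H]2CC3=N[C@H](CCC(=O)O)C(=O)O[C@]3(C)[C@@H]1C2`: 38000 nM
Compound 2, `CC(C)(C)OC(=O)CC[C@H]1N=C2C[C@H]3C[C@H](C3(C)C)[C@@]2(C)OC1=O`: 55000 nM
Compound 3, `CC1(C)N=C2C[C@H]3C[C@H](C3(C)C)[C@@]2(C)OC1=O`: 166000 nM

All three compounds were measured in a functional assay on PC-3 cells (Homo sapiens) for antiproliferative activity, read by sulforhodamine B assay, with a stated time of 48 h; on this read-out higher numbers stand for weaker inhibition and lower numbers for stronger inhibition. Compound 2 stands second highest of the three numbers. Its nearest neighbour is compound 1, and the step of a 1.4-fold higher number from compound 1 to compound 2 (0.16 log units; within the scatter) lies within the scatter, so the two cannot be ordered. Compound 3 is furthest from compound 2, and the gap between their numbers lies beyond the scatter.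

Compound 4, `CC(C)(C)OC(=O)CC[C@@H]1N=C2C[C@@H]3C[C@@H](C3(C)C)[C@]2(C)OC1=O`, has not yet been measured in this assay. It differs from compound 2 as follows: the two compounds have the same atoms and bonds and differ only in configuration as drawn: 4 of 4 stereo elements differ (all stereocentres are inverted: mirror images); a stereocentre at a saturated ring carbon is drawn R in compound 2 and S in compound 4; a stereocentre at a saturated ring carbon is drawn R in compound 2 and S in compound 4; a stereocentre at a saturated ring carbon is drawn R in compound 2 and S in compound 4; a stereocentre at a saturated ring carbon is drawn R in compound 2 and S in compound 4

Within the data shown here, none of the measured steps bears on this change. Among the measured compounds shown here, the only step among the measured compounds, a 1.4-fold higher number from compound 1 to compound 2 (0.16 log units; within the scatter), concerns the ester and leaves every configuration untouched, and no measured pair differs in configuration at all. The data therefore give no direction for compound 4, and the expected step of no change at the digits printed from compound 2 to compound 4 (within the scatter) is set at none beyond the scatter, with a wide band to allow for either outcome. For compound 4 the estimated value in this assay is 55000 nM, with an expected range from 15000 nM to 200000 nM.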

Compound 4, half-maximal inhibitory concentration: 42000 nM
Estimate against measurement, compound 4: 1.3-fold (0.12 log units) above; the measured number falls inside the stated range.
By their numbers in this assay, from the lowest: compounds 1, 4 and 2 (each within the scatter of the next); then compound 3.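

In this assay, inverting every stereocentre of the tert-butyl ester gives a 1.3-fold lower number from compound 2 to compound 4 (0.12 log units; within the scatter), and the two mirror images therefore cannot be ordered. Among these compounds, this is the first comparison that tests configuration at all, as the earlier step touched only the ester, and it shows that changing all four stereocentres together leaves no readable difference on this read-out for this pair. The comparison is a clean one, with configuration as the only variable: the fact that compounds 2 and 4 differ only in the configuration as drawn

Going by these compounds, whether the mirror image of compound 1, with its free carboxylic acid, or of compound 3 would also stay within the scatter of its partner remains open, as does whether inverting a single stereocentre rather than all four would give a different number. Also open, on these data alone, is how a primary amine, an amide or a longer chain in place of the tert-butyl ester would read in this assay, and whether either configuration of the core would then separate from the other.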